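Bringing selenium back to a weak sulfur compound

This account rests on a few compounds, and the source may have more. Where it says the series, first, only, none or still open, it means among the compounds named here.

Compound 2 `CS/C(=N\C(=O)c1ccco1)NC(=O)c1ccco1` is tested in a functional assay on HepG2 cells (Homo sapiens) for cytotoxicity, read by MTT assay, with a stated time of 72 h; a lower number here means a stronger inhibitor of growth, a higher number a weaker inhibitor of growth. In that test compound 2 reaches only the assay limit, > 100000 nM, so no number is known for it. Compound 1 `C[Se]/C(=N\C(=O)c1ccco1)NC(=O)c1ccco1` carries a methylselanyl group where compound 2 carries methylsulfanyl; in this assay compound 1 gives 8660 nM. Among the compounds with values here, the single measured step, an at least 11-fold higher number from compound 1 to compound 2 (1.06 log units; beyond the scatter), is large, and one of its two values is the limit (the limit of > 100000 nM in this assay, at which 1 of the 2 values shown sits). Compound 3 `O=C(/N=C(/NC(=O)c1ccco1)[Se]Cc1ccccc1)c1ccco1` differs from compound 2 in the change (a group of 8 heavy atoms (7 carbon, 1 selenium; one six-membered aromatic ring of carbon only) in place of a group of 2 heavy atoms (1 carbon, 1 sulfur; no ring), on a carbon with a double bond to nitrogen), which brings selenium back together with a benzyl group. From the compounds shown here alone, because of an at least 11-fold higher number from compound 1 to compound 2 (1.06 log units; beyond the scatter), reversing that swap is expected to recover much of what compound 1 shows, though the benzyl group is untested here. Compound 3 is therefore estimated at 6000 nM, with a range from 1500 nM to 30000 nM. From compound 2 the expected step is an at least 16-fold lower number from compound 2 to compound 3 (1.22 log units; beyond the scatter).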

Compound 3, concentration for total growth inhibition: 39500 nM
For compound 3 the middle estimate is 6.6-fold (0.82 log units) below the measured one; measured number outside the range, above it.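

In this assay, the group with selenium and a benzyl carbon still gives a stronger result than the methylsulfanyl group on the carbon with a double bond to nitrogen: an at least 2.5-fold lower number from compound 2 to compound 3 (0.40 log units; beyond the scatter). Even so, selenium alone does not set the result at this place, since phenyl in place of hydrogen on the saturated chain carbon bound to selenium weakens growth inhibition, with a 4.6-fold higher number from compound 1 to compound 3 (0.66 log units; beyond the scatter). The first of these steps gives only a minimum size, as compound 2 has an assay limit and not a number: the limit of > 100000 nM in this assay, at which 1 of the 3 values shown sits.

The compounds shown leave open how a benzylsulfanyl group would compare with compound 3, a comparison that would separate the share of selenium from that of the benzyl group. They also leave open whether an ethyl chain on selenium would fall between compound 1 and compound 3.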